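Trifluoromethoxy to fluoro on the shared core

The source may report more compounds than this note shows. Statements on the series, on what has been measured and on what is new or still open speak of the compounds shown alone.

Measured so far in an ADME assay on H9c2 cells (Rattus norvegicus) for cytotoxicity; on this read-out higher numbers stand for weaker inhibition and lower numbers for stronger inhibition

- compound 1 `CC(C)(C)c1ccc2nc(NC(=O)C3CC3)sc2c1` gives 32000 nM
- compound 2 `O=C(Nc1nc2ccc(OC(F)(F)F)cc2s1)C1CC1` gives 5000 nM

Compound 2 (5000 nM) holds the lower of the two numbers. Compound 3 `O=C(Nc1nc2ccc(F)cc2s1)C1CC1` carries fluoro in place of trifluoromethoxy on an aromatic carbon. Among the measured compounds shown here, only one measured step bears on this, the swap of tert-butyl for trifluoromethoxy on an aromatic carbon (a 6.4-fold lower number from compound 1 to compound 2 (0.81 log units; beyond the scatter)), which is modest and beyond the scatter. For the measured compounds named here, a modest rise in this assay is therefore expected, though no measured step covers fluoro. The expected step is a 2.2-fold higher number from compound 2 to compound 3 (0.34 log units; beyond the scatter) ( estimated ). For compound 3 the estimate is 11000 nM, with an expected range of 4000 nM to 30000 nM.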

Compound 3, half-maximal inhibitory concentration: > 50000 nM
Compound 3: no number, only a limit; the forecaster's own chance of this, stated with the estimate: 5%; at least 4.5-fold (0.65 log units) between middle value and limit.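

In this assay compound 3 has no number, only a limit of the assay: the limit of > 50000 nM in this assay, at which 1 of the 3 values shown sits.

Fluoro on this aromatic carbon gives an at least 10-fold higher number from compound 2 to compound 3 (1.00 log units; beyond the scatter), so among the three groups shown, the low number of compound 2 goes with trifluoromethoxy and not with the shared core alone. Against tert-butyl, fluoro gives an at least 1.5-fold higher number from compound 1 to compound 3 (0.19 log units; that floor lies within the scatter), and with that floor fluoro and tert-butyl cannot be placed in order.

Open, going by these compounds, is whether a methoxy, a chloro or an amine on the same carbon would give a number as low as that of compound 2.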